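This account rests on a few compounds, and the source may have more. Where it says the series, first, only, none or still open, it means among the compounds named here.

- Compound 1 `C=CS(=O)(=O)NC/C=C/c1cc(OC)cc(O)c1C(=O)OCC1CCCCC1`: 7880 nM
- Compound 2 `CCN(CC)C/C=C/C(=O)NC/C=C/c1cc(OCCc2ccc(F)cc2)cc(O)c1C(=O)OC(C)C`: > 10000 nM
- Compound 3 `COc1cc(O)c(C(=O)OC(C)C)c(/C=C/CN2C(=O)C=CC2=O)c1`: 7320 nM

These results come from a functional assay on THP-1 cells (Homo sapiens) for antiproliferative activity, read by luminescence, with a stated time of 72 h; a higher number here means a weaker inhibitor, a lower number a stronger inhibitor. Compound 1 gives 7880 nM and compound 3 gives 7320 nM, two numbers within the usual scatter of each other. Compound 2 is reported only as a limit, > 10000 nM, and not as a number.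

Compound 4 `C=CS(=O)(=O)NC/C=C/c1cc(OC)cc(O)c1C(=O)OCc1ccc(F)cc1` keeps the core of compound 1 and changes one group: 4-fluorophenyl in place of cyclohexyl on a saturated chain carbon bound to an oxygen next to a carbonyl group. Put simply, 4-fluorophenyl stands in place of cyclohexyl on a saturated chain carbon bound to an oxygen next to a carbonyl group, so a cyclohexylmethyl ester becomes a 4-fluorobenzyl ester.

Within the data shown here, no measured pair shows this change alone, so the starting point is compound 1 at 7880 nM, and no step beyond the scatter is expected in this assay. The expected change is small, a 1.2-fold lower number from compound 1 to compound 4 (0.08 log units; within the scatter). The estimated value for compound 4 is 6500 nM, with an expected range of 2500 nM to 10000 nM.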

Compound 4, half-maximal inhibitory concentration: 6550 nM
The estimate for compound 4 lay 1.0-fold (0.00 log units) below the measured number; the range from low to high includes it.
By their numbers in this assay, from the lowest: compounds 4, 3 and 1 (each within the scatter of the next). At a limit, above all of these: compound 2.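

Turning the cyclohexylmethyl ester into a 4-fluorobenzyl ester gives a 1.2-fold lower number from compound 1 to compound 4 (0.08 log units; within the scatter) in this assay. This is the only pair shown that differs in one place, and it reveals that a non-aromatic carbon ring and a fluorine-bearing aromatic ring cannot be told apart at this position in this assay. Compound 2 differs from these compounds in more than one place and is reported only as a limit, not a number: the limit of > 10000 nM in this assay, at which 1 of the 4 values shown sits.

As far as these compounds go, whether an amine, a carboxylic acid or a longer chain at this position would give a step beyond the scatter remains open. A plain benzyl group would also be needed to separate any contribution of the fluorine from that of the aromatic ring.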